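Working notes: from compound 3 to compound 4

The source may hold more compounds than are shown below. What is called first, only, known or untested is meant among the compounds shown, and "the series" means these compounds.

In a functional assay on RAW264.7 cells (Mus musculus) for inhibition, read by Griess assay, with stated times of 3 h and 24 h (on this read-out lower numbers stand for stronger inhibition and higher numbers for weaker inhibition), the measured compounds read as follows
- compound 1 `C=C1CCC2[C@](C)(CO)[C@H](O)CC[C@@]2(C)[C@@H]1CCn1ccc(=O)[nH]c1=O` gives > 100000 nM as a limit
- compound 2 `C=C1CCC2[C@](C)(CO)[C@H](O)CC[C@@]2(C)[C@@H]1CCn1ccnc1` gives > 50000 nM as a limit
- compound 3 `C=C1CCC2[C@](C)(CO)[C@H](O)CC[C@@]2(C)[C@@H]1CCOC(=O)c1cccnc1` gives > 50000 nM as a limit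

None of the three compounds has a number of its own. Compound 3 stands at the limit of > 50000 nM in this assay, at which 2 of the 3 values shown sit, and so has no number to start from. The next structure, compound 4 `C=C1CCC2[C@](C)(CO)[C@H](O)CC[C@@]2(C)[C@@H]1CCOC(=O)c1ccc([N+](=O)[O-])cc1`, keeps the shared core and carries 4-nitrophenyl in place of pyridin-3-yl on a carbonyl carbon. The nearest measured change is a step that the two limits leave unreadable from compound 2 to compound 3 and the other two are a step that the two limits leave unreadable from compound 1 to compound 2 and a step that the two limits leave unreadable from compound 1 to compound 3 so no size can be taken from any of them. With no readable step, no direction can be argued from the data, and no change beyond the scatter is assumed. The expectation rests on compound 3 with its limit of > 50000 nM and on nothing finer. The expected move is a number no higher from compound 3 to compound 4 (the limit leaves the size open) and it carries little weight. Estimated for compound 4 is 50000 nM with an expected range from 15000 nM to 100000 nM in this assay and a report as a limit is the likelier outcome.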

Compound 4, half-maximal inhibitory concentration: 37300 nM
The estimate for compound 4 lay 1.3-fold (0.13 log units) above the measured number; the range from low to high includes it.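

In this assay, within the data shown here, the steps among compound 1, compound 2 and compound 3 cannot be read, whereas compound 4 gives 37300 nM, the first number of its own in this set and a measured reference for the group on the carbonyl carbon. Placing 4-nitrophenyl in place of pyridin-3-yl on a carbonyl carbon gives an at least 1.3-fold lower number from compound 3 to compound 4 (0.12 log units; that floor lies within the scatter), so this is the first step with a readable direction, although its floor does not establish a change beyond the scatter and its true size remains open. The starting value for compound 3 is a limit and not a number: the limit of > 50000 nM in this assay, at which 2 of the 4 values shown sit.

The compounds shown do not separate the contribution of the nitro group from that of the carbon-only aromatic ring, nor from the change in group size, and a plain phenyl or a 4-aminophenyl on the same carbonyl carbon would bear on that question. On these data alone, it also remains open how a saturated group such as cyclohexyl, or a longer chain ending in a carboxylic acid, would read at this place in this assay.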